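One stereocentre changed: compound 3 to compound 4

The source may report more compounds than this note shows. Statements on the series, on what has been measured and on what is new or still open speak of the compounds shown alone.

In an ADME assay on Vero cells (Chlorocebus sabaeus) for cytotoxicity, read by MTT assay, with a stated time of 72 h (a lower number here means that less compound is tolerated, a higher number that more compound is tolerated), compound 3 `COc1cccc([C@H](O)COC(=O)/C=C/c2ccccc2)c1OC` gives 28400 nM, which lies within the scatter of the two other measured compounds. Compound 2 `COc1cccc([C@@H](O)COC(=O)/C=C/c2ccccc2)c1` gives 22300 nM and compound 1 `COc1ccccc1[C@@H](O)COC(=O)/C=C/c1ccccc1` gives 51700 nM.

Compound 4 `COc1cccc([C@@H](O)COC(=O)/C=C/c2ccccc2)c1OC` has the same atoms and bonds as compound 3: the two compounds have the same atoms and bonds and differ only in configuration as drawn: 1 of 2 stereo elements differ; a stereocentre at a saturated chain carbon is drawn S in compound 3 and R in compound 4. Among the measured compounds shown here, no measured pair shows what a change of configuration alone does in this assay. No step beyond the scatter is therefore expected, and neither direction is favoured, so the expectation stays anchored on compound 3 at 28400 nM.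

The estimated change is a 1.1-fold higher number from compound 3 to compound 4 (0.02 log units; within the scatter), which would lie within the scatter. The expected value for compound 4 is 30000 nM, with an estimated range of 15000 nM to 60000 nM.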

Compound 4, half-maximal cytotoxic concentration: 82700 nM
Compound 4: the middle estimate sits 2.8-fold (0.44 log units) below what was measured; the whole stated range lies below it.
By their numbers in this assay, from the lowest: compounds 2, 3, 1 and 4 (each within the scatter of the next, the first and the last beyond it).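

In this assay, among the compounds shown here, inverting the stereocentre at the saturated chain carbon gives a 2.9-fold higher number from compound 3 to compound 4 (0.46 log units; beyond the scatter), the first step attributable to configuration alone: the fact that compounds 3 and 4 differ only in the configuration as drawn. Methoxy in place of hydrogen on an aromatic carbon gives a 3.7-fold higher number from compound 2 to compound 4 (0.57 log units; beyond the scatter), beyond the scatter. The same replacement gives a 1.6-fold higher number from compound 1 to compound 4 (0.20 log units; within the scatter), within the scatter, so its reading depends on the compound compared. As far as these compounds go, whether inverting the stereocentre has a similar effect in compound 1 or compound 2 remains open, as does the effect of an amine or a carboxylic acid in place of a methoxy group.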